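Compound 4 from compound 2: tert-butyl for fluoro

This account rests on a few compounds, and the source may have more. Where it says the series, first, only, none or still open, it means among the compounds named here.

Measured in a functional assay on SMMC-7721 cells (Homo sapiens) for inhibition, read by CCK-8 assay, with a stated time of 72 h, tested at 8 uM; on this read-out higher numbers stand for more inhibition of growth at the one concentration tested and lower numbers for less inhibition of growth:
Compound 1 `Nc1ccccc1NC(=O)c1ccc(CSc2nccc(C(F)(F)F)n2)cc1` — 80.6%
Compound 2 `Nc1ccccc1NC(=O)/C=C/c1ccc(CSc2ccc(F)cc2)cc1` — 15.4%
Compound 3 `Cc1ccc(SCc2ccc(C(=O)Nc3ccccc3N)cc2)cc1` — 82.7%

Compound 2 stands lowest of the three numbers. Its nearest neighbour is compound 1, whose value lies well beyond the scatter above it, and compound 3 lies further still, also beyond the scatter. Going by the values given here, no pair among the measured compounds differs in one place only, so nothing more than the bare values can be read from the gaps between compound 2 and the other two; compound 1 and compound 3 lie within the scatter of each other and are not ranked.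

Compound 4 `CC(C)(C)c1ccc(SCc2ccc(/C=C/C(=O)Nc3ccccc3N)cc2)cc1` is not yet measured. It differs from compound 2 in one place: tert-butyl in place of fluoro on an aromatic carbon.

Among the compounds with values here, with no single-point step in the measured set to lean on, the expected size of the change in this assay is uncertain; a modest rise is expected from compound 2 to compound 4, of a size that may stay within the scatter, and a fall is not expected. The estimated step is a number 10.6 percentage points higher from compound 2 to compound 4 (beyond the scatter). For compound 4 the expected value is 26%, with a range from 8% to 55%.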

Compound 4, percent growth inhibition at one concentration: 23.6%
Beside the measured number, compound 4's estimate is 2.4 percentage points above it; the measured number falls inside the stated range.
By their numbers in this assay, from the lowest: compounds 2 and 4 (each within the scatter of the next); then compounds 1 and 3 (each within the scatter of the next).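

In this assay, going by these compounds alone, this is the first step that changes one place only: tert-butyl, with 4 heavy atoms, takes the place of fluoro, with 1 heavy atom, on an aromatic carbon para to a large group, and the result is a number 8.2 percentage points higher from compound 2 to compound 4 (within the scatter) with no further comment needed on direction. At this position, then, the change from 4-fluorophenyl to 4-(tert-butyl)phenyl gives no difference that can be told from the usual spread of repeated measurements, so compound 2 and compound 4 are not ranked, and this one pair shows that the carbon accepts the larger group without a resolved change in growth inhibition at the one concentration tested. No measurement shown here bears on the reason for this outcome.

The compounds shown leave open whether an amine, a carboxylic acid or a longer alkyl chain on this same aromatic carbon would give a step beyond the scatter. Within the data shown here, they also leave open whether tert-butyl in place of fluoro would read the same way on a core other than the one shared by compound 2 and compound 4.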